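The source may hold more compounds than are shown below. What is called first, only, known or untested is meant among the compounds shown, and "the series" means these compounds.

Working notes on the series. Compound 1 `Fc1cc(Nc2cc(Nc3ccc(Cl)cc3)ncn2)ccc1Oc1ccncc1-c1cccnc1` and compound 2 `Fc1ccc(Nc2cc(Nc3ccc(Oc4ccncc4-c4cccnc4)c(F)c3)ncn2)cc1` share one core, while compound 3 `Cn1c(=O)c(C(=O)Nc2ccc(Oc3ccncc3-c3cccnc3)c(F)c2)nn(-c2ccc(Cl)cc2)c1=O` carries the other core of the set. In a functional assay on A549 cells (Homo sapiens) for cytotoxicity, read by MTT assay, with a stated time of 72 h (a higher number here means a weaker inhibitor, a lower number a stronger inhibitor), compound 1 gives 1610 nM, compound 2 gives 710 nM and compound 3 gives 930 nM. Compound 3 therefore stands second highest of the three numbers; its gaps to compound 2 and to compound 1 both lie within the scatter, so no order among them can be claimed. Going by the values given here, the only single-point step measured is a 2.3-fold lower number from compound 1 to compound 2 (0.36 log units; beyond the scatter), a halogen exchange on an aromatic carbon of the other core. Compound 4 `Cn1c(=O)c(C(=O)Nc2ccc(Oc3ccncc3-c3cccnc3)c(F)c2)nn(-c2ccc(F)c(Cl)c2)c1=O` differs from compound 3 by 3-chloro-4-fluorophenyl in place of 4-chlorophenyl on an aromatic nitrogen. The measured step bears on this change only loosely: it exchanges one halogen for another rather than adding a second one, and it sits on a different core. It suggests that halogen changes on that aromatic ring move this assay modestly at most. The expectation for the change from compound 3 to compound 4 is therefore no step beyond the scatter, a 1.2-fold lower number from compound 3 to compound 4 (0.07 log units; within the scatter). Compound 4 is estimated at 800 nM, with a range from 300 nM to 2500 nM.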

Compound 4, half-maximal inhibitory concentration: 12500 nM
Compound 4: the middle estimate sits 16-fold (1.19 log units) below what was measured; the measured number lies above the stated range.
By their numbers in this assay, from the lowest: compounds 2, 3 and 1 (each within the scatter of the next, the first and the last beyond it); then compound 4.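

On the core of compound 3, the aryl group on the aromatic nitrogen is far from indifferent in this assay: going to 3-chloro-4-fluorophenyl gives a 13-fold higher number from compound 3 to compound 4 (1.13 log units; beyond the scatter), a large loss from a change of one heavy atom in count. Going by these compounds alone, the only earlier halogen step, a 2.3-fold lower number from compound 1 to compound 2 (0.36 log units; beyond the scatter), sits on the other core and is modest, so it gave no sign of a change this size, and compound 4 now stands alone at the weak end of the series. Nothing measured here accounts for the loss.

The change moves the chlorine and adds a fluorine together, so the compounds shown cannot say which of the two carries the step. They also leave open how an unsubstituted phenyl, or a phenyl bearing a methoxy or a dimethylamino group, would behave at this position.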